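Dimethylamino in place of amino on the shared core

The source may report more compounds than this note shows. Statements on the series, on what has been measured and on what is new or still open speak of the compounds shown alone.

Compound 1 `CN1CCC[C@H]1[C@@H]1COc2ccc(N)cc2O1`: 19 nM
Compound 2 `CN1CCC[C@H]1[C@H]1COc2ccc(N)cc2O1`: 180 nM
Compound 3 `CN1CCC[C@H]1[C@@H]1COc2c(O)cccc2O1`: 3900 nM

In an assay on membranes from HEK293 cells for displacement of a labelled ligand from Neuronal acetylcholine receptor; alpha3/beta4 (Homo sapiens), with a stated time of 5 min (on this read-out higher numbers stand for weaker inhibition and lower numbers for stronger inhibition), compound 1 gives the lowest of the three numbers. Its nearest neighbour is compound 2, reached by a 9.5-fold higher number from compound 1 to compound 2 (0.98 log units; beyond the scatter), a step that rests only on (the fact that compounds 1 and 2 differ only in the configuration as drawn). Compound 3, with its own structure, shows a far higher number than compound 1 and compound 2. Compound 4 `CN(C)c1ccc2c(c1)O[C@H]([C@@H]1CCCN1C)CO2` differs from compound 1 by dimethylamino in place of amino on an aromatic carbon. Among the compounds with values here, no measured step touches this position, so the expectation rests on compound 1 alone. The change is expected to give a step of a 2.1-fold higher number from compound 1 to compound 4 (0.32 log units; beyond the scatter) in this assay, not clearly beyond the scatter in either direction. Compound 4 is therefore estimated at 40 nM, between 10 nM and 200 nM.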

Compound 4, inhibition constant: 2200 nM
The estimate for compound 4 lay 55-fold (1.74 log units) below the measured number, outside the stated range (above it).
By their numbers in this assay, from the lowest: compound 1; then compound 2; then compounds 4 and 3 (each within the scatter of the next).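

Within the data shown here, the position on the aromatic carbon, which no earlier step had touched, proves highly sensitive to this change in this assay: dimethylamino in place of amino gives a 120-fold higher number from compound 1 to compound 4 (2.06 log units; beyond the scatter). The swap adds two carbons and removes the hydrogen-bond donor at once, so the step cannot assign the loss to either difference alone.

As far as these compounds go, whether methylamino, with a single methyl on the nitrogen, would stand nearer compound 1 or compound 4 stays open. Nothing known about these compounds explains the size of the step.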